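From Chloro to Bromo: Estimating a Second Halogen Step

The source may hold more compounds than are shown below. What is called first, only, known or untested is meant among the compounds shown, and "the series" means these compounds.

Compound 1 `O=C1CC(c2ccccc2)n2ncnc2N1` is the starting point of this small set. Among the compounds with values here, in a functional assay on the whole organism (strain Kunming) with Mus musculus as the target (on this read-out lower numbers stand for an effect already at smaller amounts and higher numbers for an effect only at larger amounts of compound), compound 1 gives 51.9 mg/kg, the highest of the two numbers measured so far. Within the data shown here, its one neighbour, compound 2 `O=C1CC(c2ccccc2Cl)n2ncnc2N1`, gives 25.5 mg/kg in this assay, and the step of a 2.0-fold lower number from compound 1 to compound 2 (0.31 log units; beyond the scatter) shows that chloro in place of hydrogen on an aromatic carbon lowered the number modestly. Compound 3 `O=C1CC(c2cccc(Br)c2)n2ncnc2N1` has not yet been measured. It differs from compound 1 by bromo in place of hydrogen on an aromatic carbon. Among the measured compounds shown here, only the step from compound 1 to compound 2 bears on this change: both place a halogen on the same six-membered aromatic ring, though not on the same carbon, so it is an imperfect guide. A lowering of similar or somewhat smaller size is therefore expected in this assay. Compound 3 is expected to give 35 mg/kg, within 17 mg/kg to 70 mg/kg, which means an estimated step of a 1.5-fold lower number from compound 1 to compound 3 (0.17 log units; within the scatter).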

Compound 3, dose for half-maximal effect: 84.9 mg/kg
Compound 3: the middle estimate sits 2.4-fold (0.38 log units) below what was measured; the measured number lies above the stated range.
By their numbers in this assay, from the lowest: compound 2; then compounds 1 and 3 (each within the scatter of the next).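

At this carbon, meta to a large group, bromo in place of hydrogen gives a 1.6-fold higher number from compound 1 to compound 3 (0.21 log units; within the scatter) in this assay and the two compounds therefore cannot be told apart on this read-out. Within the data shown here, the chloro change gave a 2.0-fold lower number from compound 1 to compound 2 (0.31 log units; beyond the scatter) and remains the only step here that clears the scatter, so compound 3 goes against any rule that a halogen on this ring lowers the number. Nothing available explains why the two halogen steps differ.

The two steps change both the halogen and the carbon it sits on, so they leave open which of these matters, and chloro on the carbon that carries bromo in compound 3 would separate the two. Going by these compounds, how an amine or a carboxylic acid would behave on this carbon also remains open.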